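Ether substituent series on the shared core

This account rests on a few compounds, and the source may have more. Where it says the series, first, only, none or still open, it means among the compounds named here.

Compound 1 `Cc1ccc(Oc2ccc(C(=O)N3CCOC3=O)cc2)cc1` carries a 4-methylphenyl on an oxygen on an aromatic ring; in an assay on HEK293 cells for inhibition of N-acylethanolamine-hydrolyzing acid amidase (Rattus norvegicus), read by LC-MS, with a stated time of 30 min (on this read-out higher numbers stand for weaker inhibition and lower numbers for stronger inhibition), compound 1 gives 6400 nM. Compound 2 `O=C1OCCN1C(=O)c1ccc(OC2CCCCC2)cc1` has cyclohexyl at the same oxygen, and in this assay compound 2 gives 92 nM. Compound 3 `CCC(CC)Oc1ccc(C(=O)N2CCOC2=O)cc1` has pentan-3-yl there; in this assay compound 3 gives 480 nM, the second highest of the three numbers, with a 5.2-fold higher number from compound 2 to compound 3 (0.72 log units; beyond the scatter) and a 13-fold lower number from compound 1 to compound 3 (1.12 log units; beyond the scatter). The remaining pair shows a 70-fold lower number from compound 1 to compound 2 (1.84 log units; beyond the scatter).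

Compound 4 `CCCCCCOc1ccc(C(=O)N2CCOC2=O)cc1` differs from compound 3 by hexyl in place of pentan-3-yl on an oxygen on an aromatic ring. Going by the values given here, no measured step exchanges one open chain for another at this oxygen; the steps that bear on it swap a ring for a chain or one ring for another. The step from compound 2 to compound 3 is the closest in kind and modest in size, and it shows that a change among the saturated groups can move the number. Without a chain-to-chain comparison, the expectation for compound 4 is a 1.6-fold lower number from compound 3 to compound 4 (0.20 log units; within the scatter), no step beyond the scatter. The estimate for compound 4 is 300 nM, range 100 nM to 1000 nM.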

Compound 4, half-maximal inhibitory concentration: 640 nM
Estimate against measurement, compound 4: 2.1-fold (0.33 log units) below, within the range that was stated.
By their numbers in this assay, from the lowest: compound 2; then compounds 3 and 4 (each within the scatter of the next); then compound 1.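

In this assay, going by these compounds alone, the first exchange of one open chain for another at this oxygen, a 1.3-fold higher number from compound 3 to compound 4 (0.12 log units; within the scatter), does not separate hexyl from pentan-3-yl. Hexyl also stands apart from both ring groups, with a 7.0-fold higher number from compound 2 to compound 4 (0.84 log units; beyond the scatter) and a 10-fold lower number from compound 1 to compound 4 (1.00 log units; beyond the scatter), so among these four compounds both open chains fall between cyclohexyl and 4-methylphenyl. Nothing at hand gives a reason for these differences.

As far as these compounds go, whether a longer chain such as octyl stays with hexyl and pentan-3-yl remains open. Also open, from the compounds shown here alone, is where a smaller saturated ring such as cyclopentyl, or an unsubstituted phenyl, would fall relative to cyclohexyl and 4-methylphenyl.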